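The compounds below may be only part of what the source reports. "The series", "measured", "known", "first", "only" and "open" are said of these compounds alone.

Working notes on the series, cytotoxicity read on splenocytes.

Three compounds have numbers in an ADME assay on cells (Splenocyte, Mus musculus, strain BALB/c) for cytotoxicity, read by MTT assay, tested at 10 ug/mL; on this read-out lower numbers stand for a weaker effect and higher numbers for a stronger effect at the one concentration tested. Compound 1 `CCCCCCCCCCCCCCC(NC(=O)OC(C)(C)C)C(=O)O` gives 5.1%, the lowest of the three. Compound 2 `CCCCCCCCCCCCCCC(COCc1ccccc1)NC(=O)CCCC(=O)O` gives 6.4%, which lies within the scatter of compound 1. Within the data shown here, compound 3 `CCCCCCCCCCCCCCC(CO)NC(=O)CCCC(=O)OC` gives 18.9%, a number beyond the scatter above compound 1; no single-place step joins it to compound 1, so the two values are set side by side only.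

Compound 4 `CCCCCCCCCCCCCCC(CN(CC)CC)NC(=O)OC(C)(C)C` is not yet measured in this assay. From compound 1 it differs in one place: (diethylamino)methyl in place of carboxy on a saturated chain carbon bound to an amide-type nitrogen and a saturated chain carbon. Among the measured compounds shown here, no step between measured compounds maps this change, so no measured size can be borrowed for it. The expectation rests on the spread seen so far: the numbers run from the value of compound 1 to the value of compound 3, and a compound without the carboxy has given the higher of these two. For compound 4 a step of modest size upward, in the expected range a number 9.9 percentage points higher from compound 1 to compound 4 (within the scatter), is estimated, because compound 3 gives 18.9% while keeping an amide-type nitrogen on the same kind of chain carbon. For the measured compounds named here, the estimate for compound 4 is therefore 15%, with a range from 3% to 35%; only three numbers stand behind it, so the range is kept wide.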

Compound 4, a percentage reported as activity, at one concentration (the size of the read-out at that concentration, not a potency): 7.8%
Beside the measured number, compound 4's estimate is 7.2 percentage points above it; measured number inside the range.
By their numbers in this assay, from the lowest: compounds 1, 2 and 4 (each within the scatter of the next); then compound 3.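

In this assay, among these compounds, the first single-place step comes from putting (diethylamino)methyl in place of carboxy on a saturated chain carbon bound to an amide-type nitrogen and a saturated chain carbon, and it reads as a number 2.7 percentage points higher from compound 1 to compound 4 (within the scatter). At this place, then, the read-out does not separate the two groups, even though the entering group has more heavy atoms, brings in nitrogen, and has no hydrogen-bond donor, whereas the carboxy it replaces has one. No measurement at hand explains this result.

This single pair cannot show whether the same holds for other groups at this place, such as a primary amine or a primary amide, or whether either would be separated from carboxy in this read-out. It also leaves open whether the tert-butoxycarbonyl group on the nitrogen or the length of the chain shapes the outcome, and a shorter chain or an acetyl group on that nitrogen could give a different picture for the same exchange.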